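Swapping the aryl arm on a thiazole antagonist scaffold

The source may hold more compounds than are shown below. What is called first, only, known or untested is meant among the compounds shown, and "the series" means these compounds.

Measured compounds:
compound 1 `CS(=O)(=O)Nc1cccc(-c2nc(C(c3ccc(F)cc3)c3ccc(F)cc3)sc2CC(=O)O)c1` with 80%
compound 2 `O=C(O)Cc1sc(CS(=O)(=O)c2ccc(Cl)cc2)nc1-c1ccc(Cl)cc1` with 30%
compound 3 `O=C(O)Cc1sc(C(Cc2ccccc2)c2ccccc2)nc1-c1ccc(Cl)cc1` with 50%

In an in vitro functional assay on HEK285-7 cells for antagonist activity at prostaglandin D2 receptor 2 (Homo sapiens), read by BRET and beta-arrestin recruitment (a higher number here means a larger maximal response, a lower number a smaller maximal response), compound 1 gives the highest of the three numbers; compound 3 lies lower and compound 2 lower still, both gaps beyond the scatter. Going by these compounds, compound 4 `O=C(O)Cc1sc(C(c2ccc(F)cc2)c2ccc(F)cc2)nc1-c1ccnc(O)c1` is untested. It differs from compound 1 in one place: 2-hydroxypyridin-4-yl in place of 3-(methanesulfonamido)phenyl on an aromatic carbon. Within the data shown here, the two compounds with lower values carry a different group in that place, so the aryl arm seems to matter, but no single-change step is available to size its effect. A moderate downward step is expected, a number 20 percentage points lower from compound 1 to compound 4 (beyond the scatter). For compound 4 the estimate is 60%, within 35% to 85%.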

Compound 4, largest response reached (reported as efficacy), in percent of the reference or control that the assay uses: 60%
The estimate for compound 4 equals the measured number at the digits printed, within the range that was stated.
By their numbers in this assay, from the lowest: compound 2; then compounds 3 and 4 (each within the scatter of the next); then compound 1.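

In this assay, the exchange of 3-(methanesulfonamido)phenyl for 2-hydroxypyridin-4-yl on this aromatic carbon gives a number 20 percentage points lower from compound 1 to compound 4 (beyond the scatter) and thereby isolates the effect of the aryl arm, with the rest of the core unchanged. The number moves although both groups have the same printed counts of hydrogen-bond donors and acceptors, so those counts alone do not fix it. No measurement shown explains the step. Going by these compounds, whether the methanesulfonamido group or the ring nitrogen and hydroxyl account for it remains open, as does how a plain phenyl or a 3-aminophenyl would read here.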